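The source may hold more compounds than are shown below. What is called first, only, known or untested is meant among the compounds shown, and "the series" means these compounds.

Measured in a functional assay with Mus musculus as the target; a higher number here means that more compound is needed for the effect, a lower number that less compound is needed:

Compound 1 `CN(C)CCCn1c(=O)n(C2OC(CO)[C@@H](O)[C@H]2O)c2nc(N)nc(O)c21`: 820 uM
Compound 2 `C=CCn1c(=O)n(C2C=CC(CO)O2)c2nc(N)nc(O)c21`: 30 uM

Compound 1 holds the higher of the two numbers, so more of it is needed for the effect than of compound 2, and this gap lies beyond the scatter. The two compounds differ in more than one place, so their gap cannot be tied to any single change.

Compound 3 `Nc1nc(O)c2c(n1)n(C1OC(CO)[C@@H](O)[C@H]1O)c(=O)n2Cc1ccc([N+](=O)[O-])cc1` has not yet been measured. It keeps the core of compound 1 and has 4-nitrophenyl in place of 2-(dimethylamino)ethyl on a saturated chain carbon bound to an aromatic nitrogen. Cut one bond further out, this reads 3-(dimethylamino)propyl to 4-nitrobenzyl.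

Among the compounds with values here, no measured pair shows this change, so any expectation is loose. Compound 1, at 820 uM, already sits high, while compound 2, at 30 uM, shows that much lower numbers can occur in this small set. A moderate move to a lower number is therefore expected, and the estimated size is a 3.7-fold lower number from compound 1 to compound 3 (0.57 log units; beyond the scatter). The estimate for compound 3 is 220 uM, with an expected range of 50 uM to 900 uM.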

Compound 3, concentration for half-maximal effect: 50 uM
Estimate against measurement, compound 3: 4.4-fold (0.64 log units) above; low and high end bracket the measured number.
By their numbers in this assay, from the lowest: compounds 2 and 3 (each within the scatter of the next); then compound 1.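

In this assay, the group on a saturated chain carbon bound to an aromatic nitrogen now has a measured effect: with the rest of compound 1 kept, 4-nitrophenyl in place of 2-(dimethylamino)ethyl gives a 16-fold lower number from compound 1 to compound 3 (1.21 log units; beyond the scatter), a large step. The earlier pair, compound 1 and compound 2, differed in more than one place, so its gap could not be tied to any single change, whereas this step comes from one place alone and shows that the group held there matters for how much compound is needed. Nothing measured here explains why this change has such an effect, so the result gives a size but no cause.

This single swap cannot show whether the step comes from gaining the aromatic ring, gaining the nitro group or losing the dimethylamino group. A plain benzyl group, a 4-methoxybenzyl group or a shorter chain ending in a carboxylic acid at the same place would help separate these possibilities, and the compounds shown include none of them.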